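The compounds below may be only part of what the source reports. "The series", "measured", "known", "first", "only" and "open" are said of these compounds alone.

Three compounds have so far been tested in an assay on isolated protein for inhibition of hexokinase-2 (Rattus norvegicus), with a stated time of 6 h, tested at 10 mM; a higher number here means more inhibition at the concentration tested (going by the name of the read-out), a lower number less inhibition:

Compound 1 `O=C(CI)NCCCCC(=O)NCCCCCCNc1ncnc2c1ncn2[C@@H]1O[C@H](COP(=O)(O)OP(=O)(O)OP(=O)(O)O)[C@@H](O)[C@H]1O` gives 0%.
Compound 2 `CN(CCCCN(C)C(=O)CCCNc1ncnc2c1ncn2[C@@H]1O[C@H](COP(=O)(O)OP(=O)(O)OP(=O)(O)O)[C@@H](O)[C@H]1O)C(=O)CCCNC(=O)CI` gives 0%.
Compound 3 `Nc1ncnc2c1nc(NCCCCCCNC(=O)CI)n2[C@@H]1O[C@H](COP(=O)(O)OP(=O)(O)OP(=O)(O)O)[C@@H](O)[C@H]1O` gives 0%.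

All three share the same core and carry a chain ending in an iodoacetamide-type group, and none of them shows inhibition at the concentration tested. On these numbers compound 1 stands level with compounds 2 and 3 at the digits reported; the nearest to it is compound 2 and the furthest is compound 3, and in neither case does the gap reach beyond the usual scatter of repeated measurements of this kind. For the measured compounds named here, no pair of measured compounds differs in only one place, so no measured step is available to guide an expectation for a new compound; only the flat readings themselves can do so.

Compound 4 `O=C(CI)NCCCCCCCCNc1ncnc2c1ncn2[C@@H]1O[C@H](COP(=O)(O)OP(=O)(O)OP(=O)(O)O)[C@@H](O)[C@H]1O` differs from compound 1 in a single place: a group of 7 heavy atoms (4 carbon, 1 nitrogen, 1 oxygen, 1 iodine; no ring) in place of a group of 12 heavy atoms (7 carbon, 2 nitrogen, 2 oxygen, 1 iodine; no ring), on a saturated chain carbon, six bonds along the chain from a nitrogen on an aromatic ring. The 2-(((iodomethyl)carbonyl)amino)ethyl group that enters sits on a saturated chain carbon, six bonds along the chain from a nitrogen on an aromatic ring.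

Because compound 1 gives 0%, and compounds 2 and 3 read the same despite their differences in structure, the step from compound 1 to compound 4 is expected to be none beyond the scatter, no change at the digits printed from compound 1 to compound 4 (within the scatter). Compound 4 is therefore estimated at 0%, within a range from 0% to 10%.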

Compound 4, a percentage reported as inhibition, at one concentration (the size of the read-out at that concentration, not a potency): 41%
The estimate for compound 4 lay 41 percentage points below the measured number, and the stated range ends below it.
By their numbers in this assay, from the lowest: compounds 1, 2 and 3 (each within the scatter of the next); then compound 4.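

In this assay, this place on the chain, six bonds along from a nitrogen on an aromatic ring, proves able to move the reading: putting the 2-(((iodomethyl)carbonyl)amino)ethyl group in place of the larger group of 12 heavy atoms gives a number 41 percentage points higher from compound 1 to compound 4 (beyond the scatter) and is the first change shown to lift a compound off the flat level. Compound 1 and compound 4 both end in the same iodine-bearing carbonyl unit, so having that end does not by itself settle the reading; what differs is the group that carries it, with 1 hydrogen-bond donor and 1 acceptor entering where 2 of each leave. Nothing available explains why this change raises the reading.

This one pair ties two changes together, a smaller group and the loss of the inner amide, and the compounds shown do not separate them. A plain carbon chain of the same length as the chain in compound 1, or a longer chain, or an amine within the chain, would show which of the two counts, and whether the trend continues beyond compound 4.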